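The compounds below may be only part of what the source reports. "The series", "measured", "known", "first", "only" and "open" are said of these compounds alone.

Measured compounds in a functional assay on the whole organism (strain Sprague-Dawley) for inhibition, with Rattus norvegicus as the target; a higher number here means that more compound is needed for the effect, a lower number that less compound is needed:
- compound 1 `O=c1c(-c2nn[nH]n2)c[nH]c2c(Cl)cccc12`: 0.078 mg/kg
- compound 2 `CCc1cccc2c(=O)c(-c3nn[nH]n3)c[nH]c12`: 0.312 mg/kg

Compound 2 holds the highest of the two numbers; its nearest neighbour is compound 1, and the step of a 4.0-fold higher number from compound 1 to compound 2 (0.60 log units; beyond the scatter) is beyond the scatter. The next compound, compound 3 `CS(=O)(=O)c1cccc2c(=O)c(-c3nn[nH]n3)c[nH]c12`, is not yet measured in this assay.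

Change from compound 2 to compound 3: methylsulfonyl in place of ethyl on an aromatic carbon

Among the compounds with values here, only one measured step exists, and it swaps chloro for ethyl on the same aromatic carbon; neither of its two groups is the entering methylsulfonyl, so it bears on the new step only by showing that this position is sensitive, with a modest shift at the ethyl end. Within the data shown here, no measured pair carries methylsulfonyl. The expected step of a 1.6-fold higher number from compound 2 to compound 3 (0.20 log units; within the scatter) is therefore set close to no change, with a wide range. For compound 3 the estimate in this assay is 0.5 mg/kg, expected between 0.12 mg/kg and 2 mg/kg.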

Compound 3, minimum effective dose: 10 mg/kg
Compound 3: middle estimate off by 20-fold (1.30 log units), on the low side, and the stated range ends below it.
By their numbers in this assay, from the lowest: compound 1; then compound 2; then compound 3.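

In this assay this aromatic carbon tolerates far less than the chloro-to-ethyl swap suggested: methylsulfonyl in place of ethyl gives a 32-fold higher number from compound 2 to compound 3 (1.51 log units; beyond the scatter) and is a large step where the earlier one was modest. Against chloro, the same group gives a 130-fold higher number from compound 1 to compound 3 (2.11 log units; beyond the scatter) and places compound 3 as the compound needing the most dose of the three, with both of its steps beyond the scatter. No supporting measurement accompanies these doses, so the data give no explanation for the shift.

From the compounds shown here alone, three groups on one carbon set no trend, so it remains open whether a methoxy, an amine or a nitrile here would fall nearer chloro or methylsulfonyl. Going by these compounds, it also remains open whether methylsulfonyl on another carbon of this ring would carry the same penalty.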